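The source may report more compounds than this note shows. Statements on the series, on what has been measured and on what is new or still open speak of the compounds shown alone.

For the measured compounds named here, compound 1 `CC(C)=CCc1cc(C(=O)Nc2cc3ccc(OCC4CCN(C)C4)c(C)c3oc2=O)ccc1O` gives 1550 nM in a functional assay on MCF7 cells (Homo sapiens) for antiproliferative activity (on this read-out lower numbers stand for stronger inhibition and higher numbers for weaker inhibition), the highest of the three numbers measured so far, although neither of the other two stands beyond the scatter from it. Compound 2 `CC(C)=CCc1cc(C(=O)Nc2cc3ccc(OCCCN(C(C)C)C(C)C)c(C)c3oc2=O)ccc1O` gives 1310 nM and compound 3 `CC(C)=CCc1cc(C(=O)Nc2cc3ccc(OCCCNC(C)(C)C)c(C)c3oc2=O)ccc1O` gives 950 nM. The steps of a 1.2-fold lower number from compound 1 to compound 2 (0.07 log units; within the scatter) and a 1.6-fold lower number from compound 1 to compound 3 (0.21 log units; within the scatter) both exchange the same group at the same place as the change now considered, and both remain within the scatter. Compound 4 `COC(=O)CNCCCOc1ccc2cc(NC(=O)c3ccc(O)c(CC=C(C)C)c3)c(=O)oc2c1C` differs from compound 1 by 2-(((methoxycarbonyl)methyl)amino)ethyl in place of 1-methylpyrrolidin-3-yl on a saturated chain carbon bound to an oxygen on an aromatic ring. Since the earlier exchanges at this place moved the number little, no step beyond the scatter is expected here either, with at most a slight lowering. Compound 4 is therefore estimated at 1200 nM, within a range of 500 nM to 2900 nM. That estimate is expected to amount to a 1.3-fold lower number from compound 1 to compound 4 (0.11 log units; within the scatter).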

Compound 4, half-maximal inhibitory concentration: 2820 nM
The estimate for compound 4 lay 2.4-fold (0.37 log units) below the measured number; measured number inside the range.
By their numbers in this assay, from the lowest: compounds 3, 2, 1 and 4 (each within the scatter of the next, the first and the last beyond it).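

With the 2-(((methoxycarbonyl)methyl)amino)ethyl group, this place gives its first steps beyond the scatter: a 3.0-fold higher number from compound 3 to compound 4 (0.47 log units; beyond the scatter) and a 2.2-fold higher number from compound 2 to compound 4 (0.33 log units; beyond the scatter) are both modest, while a 1.8-fold higher number from compound 1 to compound 4 (0.26 log units; within the scatter) stays within it. The substituent on the amine nitrogen can therefore raise the number, as (methoxycarbonyl)methyl in place of tert-butyl shows. No evidence at hand accounts for this rise.

On these data alone, it remains open whether the rise follows the ester, which a carboxylic acid or a primary amide in its place could test. Also open, as far as these compounds go, is how a longer chain would affect the number.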